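Back from an amide to an amine chain

The compounds below may be only part of what the source reports. "The series", "measured", "known", "first", "only" and "open" are said of these compounds alone.

Of the compounds shown here, two sharing one core have been measured in an assay on VSM-A10 cells for antagonist activity at Endothelin-1 receptor (Rattus norvegicus); on this read-out higher numbers stand for weaker inhibition and lower numbers for stronger inhibition. Compound 1 `CCCCCNc1cccc2c(S(=O)(=O)Nc3onc(C)c3C)cccc12` carries a pentyl chain on the ring nitrogen, and in this assay compound 1 gives 80 nM. Compound 2 `Cc1noc(NS(=O)(=O)c2cccc3c(NC(=O)C(C)C)cccc23)c1C` has an isopropylcarbonyl group on that nitrogen instead, and compound 2 gives 880 nM. Going by the values given here, the only measured step, an 11-fold higher number from compound 1 to compound 2 (1.04 log units; beyond the scatter), leaves compound 2 as the higher of the two numbers, that is, the weaker inhibitor of the pair.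

Compound 3 `Cc1noc(NS(=O)(=O)c2cccc3c(NCCCCCc4ccccc4)cccc23)c1C` has not yet been measured. It differs from compound 2 in one place: 5-phenylpentyl in place of isopropylcarbonyl on a nitrogen on an aromatic ring. This removes the group whose arrival came with the large loss and restores a carbon chain of the kind seen in compound 1, now ending in a phenyl ring. Because the step of an 11-fold higher number from compound 1 to compound 2 (1.04 log units; beyond the scatter) ran the opposite way, compound 3 is expected to show a 15-fold lower number from compound 2 to compound 3 (1.17 log units; beyond the scatter). Compound 3 is therefore estimated to give about 60 nM in this assay, with a likely range from 15 nM to 250 nM.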

Compound 3, half-maximal inhibitory concentration: 3050 nM
Beside the measured number, compound 3's estimate is 51-fold (1.71 log units) below it, and the stated range ends below it.
By their numbers in this assay, from the lowest: compound 1; then compound 2; then compound 3.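

At this nitrogen, removing the carbonyl does not by itself bring back a low number in this assay: replacing isopropylcarbonyl with 5-phenylpentyl gives a 3.5-fold higher number from compound 2 to compound 3 (0.54 log units; beyond the scatter), so the number rises further instead of falling. Going by these compounds alone, the comparison with the plain pentyl chain is more telling, since the only change is phenyl in place of hydrogen on a saturated chain carbon, five bonds along the chain from the nitrogen, and it gives a 38-fold higher number from compound 1 to compound 3 (1.58 log units; beyond the scatter). The low number of compound 1 therefore cannot be credited to just any carbon chain on this nitrogen, since what stands on the chain matters a great deal, and compound 3 is the weakest inhibitor of the three.

Still open, from the compounds shown here alone, is whether the rise follows the phenyl ring itself or the greater size of the whole group, a question that a hexyl chain or a benzyl group on the same nitrogen would help to separate. Nothing shown here offers an explanation for the effect of adding the ring.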